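The compounds below may be only part of what the source reports. "The series", "measured", "known", "first", "only" and "open" are said of these compounds alone.

Measured so far:
compound 1, `CCCNCc1noc(Nc2nc(C)nc3c2c(C)nn3-c2ccc(OC)cc2C)n1`, 84 nM
compound 2, `CCCNCc1nccn1Nc1nc(C)nc2c1c(C)nn2-c1ccc(OC)cc1C`, 400 nM

In a functional assay on CHO cells for antagonist activity at corticotropin-releasing factor receptor 1 (Homo sapiens), read by cAMP accumulation (a lower number here means a stronger inhibitor, a higher number a weaker inhibitor), compound 1 gives 84 nM, the lower of the two numbers recorded. Within the data shown here, its nearest neighbour is compound 2 with 400 nM; the one measured step is a 4.8-fold higher number from compound 1 to compound 2 (0.68 log units; beyond the scatter). That step swaps one five-membered aromatic ring for another on a nitrogen on an aromatic ring of the shared core and keeps the (propylamino)methyl arm in place.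

Compound 3, `CCC[C@@H](CO)Nc1nc(C)nc2c1c(C)nn2-c1ccc(OC)cc1C`, is not yet measured. Its change from compound 1 is 1-(hydroxymethyl)butyl in place of 3-((propylamino)methyl)-1,2,4-oxadiazol-5-yl on a nitrogen on an aromatic ring: the ring leaves entirely and an open chain carrying a hydroxyl takes its place. Among the measured compounds shown here, no measured pair covers removal of the ring, so the step from compound 1 to compound 2 is the only guide, and it shows only that exchanging the ring for a different ring moves the number modestly. For compound 3 the step of a 1.4-fold lower number from compound 1 to compound 3 (0.15 log units; within the scatter) is therefore expected to fall within the scatter, with no clear direction. The estimate for compound 3 in this assay is 60 nM, within a range from 15 nM to 250 nM.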

Compound 3, inhibition constant: 574 nM
Compound 3: the middle estimate sits 9.6-fold (0.98 log units) below what was measured; measured number above the stated range.
By their numbers in this assay, from the lowest: compound 1; then compounds 2 and 3 (each within the scatter of the next).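

In this assay, the open chain 1-(hydroxymethyl)butyl in place of 3-((propylamino)methyl)-1,2,4-oxadiazol-5-yl on a nitrogen on an aromatic ring gives a 6.8-fold higher number from compound 1 to compound 3 (0.83 log units; beyond the scatter), so at this position this ring-free group does not match the oxadiazole group, and compound 1 remains the strongest of the three. The same chain in place of 2-((propylamino)methyl)-1H-imidazol-1-yl gives a 1.4-fold higher number from compound 2 to compound 3 (0.16 log units; within the scatter), so a group with a ring and a group with no ring are not separated here, and among these compounds only the oxadiazole group stands apart. No measurement on hand accounts for any of these differences.

The change from compound 1 to compound 3 removes the ring and the propylamino arm together, so the compounds shown leave open which of the two carries the difference. A plain 3-methyl-1,2,4-oxadiazol-5-yl group without the amine arm, and an open chain bearing a propylamino amine in place of the hydroxyl, would separate these two parts, and the opposite stereoisomer of the 1-(hydroxymethyl)butyl chain remains a further open question.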